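The compounds below may be only part of what the source reports. "The series", "measured", "known", "first", "only" and "open" are said of these compounds alone.

Among the measured compounds shown here, in a functional assay (Pituitary gland cell) with Rattus norvegicus as the target (on this read-out higher numbers stand for an effect only at larger amounts of compound and lower numbers for an effect already at smaller amounts), compound 1 `CC(C)(N)CCC(=O)N[C@@H]1CCc2ccccc2N(Cc2ccc(-c3ccccc3-c3nn[nH]n3)cc2)C1=O` gives 3 uM, the lower of the two numbers measured so far. Compound 2 `CC(C)(N)CCCSC1CCc2ccccc2N(Cc2ccc(-c3ccccc3-c3nn[nH]n3)cc2)C1=O` gives 7 uM, a gap beyond the usual scatter. Compound 3 `C[C@H](O)CNC(C)(C)CNC(=O)N[C@@H]1CCc2ccccc2N(Cc2ccc(-c3ccccc3-c3nn[nH]n3)cc2)C1=O`, not yet measured, keeps the core of compound 1 and changes one group on a carbonyl carbon: (2-((2-hydroxypropyl)amino)-2-methylpropyl)amino stands in place of 3-amino-3-methylbutyl ((2-((2-hydroxypropyl)amino)-2-methylpropyl)amino in place of 3-amino-3-methylbutyl on a carbonyl carbon). For the measured compounds named here, the two measured compounds do not differ in just one place, so no measured step speaks directly to this change. Going by these compounds, with so little evidence, a wide range has to stay open. The expected step is moderate and toward a lower number, meaning an effect at smaller amounts of compound: a 3.0-fold lower number from compound 1 to compound 3 (0.48 log units; beyond the scatter). In this assay, compound 3 is estimated at 1 uM, with an expected range from 0.15 uM to 6 uM.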

Compound 3, concentration for half-maximal effect: 2.5 uM
Estimate against measurement, compound 3: 2.5-fold (0.40 log units) below; the range from low to high includes it.
By their numbers in this assay, from the lowest: compounds 3 and 1 (each within the scatter of the next); then compound 2.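

Putting (2-((2-hydroxypropyl)amino)-2-methylpropyl)amino in place of 3-amino-3-methylbutyl on the carbonyl carbon gives a 1.2-fold lower number from compound 1 to compound 3 (0.08 log units; within the scatter) in this assay. In this one pair, then, the position takes a longer group of 10 heavy atoms instead of 6, with an added oxygen, a second nitrogen and a defined stereocentre, and the read-out does not move beyond the usual scatter. Nothing measured here explains this outcome.

Going by these compounds, whether the 2-hydroxypropyl part contributes anything on its own stays open, as does the role of its defined stereocentre. Also open, on these data alone, is how the read-out would respond to a carboxylic acid or a piperidine ring on this chain.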